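From a Chlorophenyl Arm to a Hydroxyphenyl Arm

The source may hold more compounds than are shown below. What is called first, only, known or untested is meant among the compounds shown, and "the series" means these compounds.

For the measured compounds named here, compound 2 `COc1ccc(/C=C2\CCC/C(=C\c3ccc(Cl)cc3)C2=O)cc1OC` stands lowest of the two numbers so far in a functional assay on SW-620 cells (Homo sapiens) for cytotoxicity, read by MTT assay, with a stated time of 72 h; on this read-out lower numbers stand for stronger inhibition and higher numbers for weaker inhibition: compound 2 gives 5900 nM, while compound 1 `COc1cccc(/C=C2\CCC/C(=C\c3ccccc3Br)C2=O)c1OC` gives 12100 nM, a gap beyond the scatter. Compound 3 `COc1ccc(/C=C2\CCC/C(=C\c3cccc(O)c3)C2=O)cc1OC` has not been measured; it differs from compound 2 by 3-hydroxyphenyl in place of 4-chlorophenyl on a double-bonded chain carbon bound to a double-bonded ring carbon. Going by the values given here, no measured pair shows this change, so the forecast rests on the two numbers alone. The step expected here, a 1.2-fold higher number from compound 2 to compound 3 (0.07 log units; within the scatter), is small and within the scatter. For compound 3 the estimated value in this assay is 7000 nM, expected between 3000 nM and 16000 nM.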

Compound 3, half-maximal inhibitory concentration: 1900 nM
For compound 3 the middle estimate is 3.7-fold (0.57 log units) above the measured one, and the stated range ends above it.
By their numbers in this assay, from the lowest: compound 3; then compound 2; then compound 1.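

In this assay, for the compounds shown here, the arm on a double-bonded chain carbon bound to a double-bonded ring carbon proves sensitive to its substituent, with 3-hydroxyphenyl in place of 4-chlorophenyl giving a 3.1-fold lower number from compound 2 to compound 3 (0.49 log units; beyond the scatter) as the first step that can be read at this place. The entering group carries a hydrogen-bond donor and acceptor that the leaving group lacks, but no measurement shown links either to the step. Since hydroxyl and chlorine also differ in ring placement, the compounds leave open which of the two matters. On these data alone, whether a 3-methoxyphenyl or 3-aminophenyl arm would keep the lower number also remains open.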